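Trimming the chain from compound 2 to compound 3

The source may hold more compounds than are shown below. What is called first, only, known or untested is meant among the compounds shown, and "the series" means these compounds.

- compound 1 `CCCCCCCc1cc2cn(COCCO)c(O)nc-2n1`: 119000 nM
- compound 2 `CCCCCCCCc1cc2cn(COCCO)c(O)nc-2n1`: 65000 nM

Within the data shown here, in a functional assay on HEL cells (Homo sapiens) (a higher number here means that more compound is tolerated, a lower number that less compound is tolerated), compound 2 lies within the scatter of compound 1, the only other compound measured. Among the measured compounds shown here, the sole measured step is a 1.8-fold lower number from compound 1 to compound 2 (0.26 log units; within the scatter), a methyl in place of hydrogen on a saturated chain carbon.

Compound 3 (`CCCCCc1cc2cn(COCCO)c(O)nc-2n1`) has a shorter chain, and the change is hydrogen in place of propyl on a saturated chain carbon, five bonds along the chain from an aromatic carbon. This change is larger than the measured step, which offers only a weak guide since a 1.8-fold lower number from compound 1 to compound 2 (0.26 log units; within the scatter) stays within the scatter. A modest move to a higher number is expected, though two compounds establish no trend. The expected size is a 2.8-fold higher number from compound 2 to compound 3 (0.44 log units; beyond the scatter). For compound 3 the estimate is 180000 nM, with an expected range from 80000 nM to 400000 nM.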

Compound 3, half-maximal cytotoxic concentration: > 200000 nM
Compound 3: a limit, no number; the forecaster's own chance of this, stated with the estimate: 25%; middle value at least 1.1-fold (0.04 log units) from the limit.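

Hydrogen in place of propyl on a saturated chain carbon, five bonds along the chain from an aromatic carbon, gives an at least 3.0-fold higher number from compound 2 to compound 3 (0.48 log units; beyond the scatter) in this assay, the first step among these compounds that lies beyond the scatter. Hydrogen in place of ethyl at the same place gives an at least 1.6-fold higher number from compound 1 to compound 3 (0.22 log units; that floor lies within the scatter), a floor that by itself does not set those two compounds apart. Among these compounds, compound 3 carries a limit and not a number, the only one among the values shown: the limit of > 200000 nM in this assay, at which 1 of the 3 values shown sits.

From the compounds shown here alone, the full size of both steps therefore stays open, as does the true value of compound 3 in this assay. Also open, going by these compounds, is how a longer chain, or an amine or a carboxylic acid at the end of the chain, would read in this assay.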